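This account rests on a few compounds, and the source may have more. Where it says the series, first, only, none or still open, it means among the compounds named here.

In a functional assay on MKN-28 cells (Homo sapiens) for inhibition, read by sulforhodamine B assay, with a stated time of 48 h (a lower number here means a stronger inhibitor of growth, a higher number a weaker inhibitor of growth), compound 2 `CCCCCCCCCCCC[C@@H](O)[C@H]1CC[C@H]([C@H](O)CCCCCCCCCCNCc2ccnn2C)O1` gives 501 nM, and compound 1 `CCCCCCCCCCCC[C@@H](O)[C@H]1CC[C@H]([C@H](O)CCCCCCCCCCN(C)C(=O)c2ccnn2C)O1` gives 302 nM. For the measured compounds named here, the two values lie within the scatter of each other, so compound 2 has no separate standing on the numbers so far. Compound 3 `CCCCCCCCCCCC[C@@H](O)[C@H]1CC[C@H]([C@H](O)CCCCCCCCCCC(=O)Nc2ccnn2C)O1` differs from compound 2 as follows: (1-methyl-1H-pyrazol-5-yl)carbamoyl in place of ((1-methyl-1H-pyrazol-5-yl)methyl)amino on a saturated chain carbon, ten or more bonds along the chain from an oxygen on a saturated carbon and a saturated ring carbon. Going by the values given here, no measured compound carries the (1-methyl-1H-pyrazol-5-yl)carbamoyl group. Among the compounds with values here, the only measured step at this end of the chain is a 1.7-fold higher number from compound 1 to compound 2 (0.22 log units; within the scatter), which stays within the scatter. It gives weak guidance for the new group, and no shift beyond the scatter is expected in this assay. The estimate amounts to a 1.3-fold lower number from compound 2 to compound 3 (0.10 log units; within the scatter), an expected step with no firm direction. Compound 3 is expected at 400 nM, with an estimated range of 150 nM to 1000 nM.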

Compound 3, concentration for 50% growth inhibition: 18200 nM
Estimate against measurement, compound 3: 46-fold (1.66 log units) below; measured number outside the range, above it.
By their numbers in this assay, from the lowest: compounds 1 and 2 (each within the scatter of the next); then compound 3.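

In this assay, this chain end proves far less tolerant than the earlier pair suggested: the change gives a 36-fold higher number from compound 2 to compound 3 (1.56 log units; beyond the scatter) and, against the other comparator, a 60-fold higher number from compound 1 to compound 3 (1.78 log units; beyond the scatter). A carbonyl alone does not mark the loss, since compound 1 also carries one and stays within the scatter of compound 2; among these three compounds, the weak one is the only one with the carbonyl carbon, rather than a nitrogen, on the saturated chain carbon. No evidence here explains the loss.

Open, as far as these compounds go, is whether the amide hydrogen of compound 3 or the placement of its carbonyl on the chain goes with the loss, a question that a carbamoyl group with a methyl on its nitrogen would address. Also open, from the compounds shown here alone, is how a plain amine or a carboxylic acid would read at this chain end.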